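The source may report more compounds than this note shows. Statements on the series, on what has been measured and on what is new or still open speak of the compounds shown alone.

Compound 1 `Cc1noc(C)c1[C@@H]1C[C@@](C)(c2ccc(F)cc2F)N=C(N)S1`: 72%
Compound 2 `CCc1noc(C)c1[C@@H]1C[C@@](C)(c2ccc(F)cc2F)N=C(N)S1`: 41%
Compound 3 `Cc1nocc1[C@@H]1C[C@@](C)(c2ccc(F)cc2F)N=C(N)S1`: 80%

These values come from an ADME assay on microsomes from liver (Mus musculus) for metabolic stability, with a stated time of 10 min, tested at 0.5 uM (a higher number here means that more of the compound is left, a lower number that less of the compound is left), and the three compounds differ only in the aromatic group on the shared core. Compound 3 cannot be told apart from compound 1, as the comparison shows a number 8 percentage points higher from compound 1 to compound 3 (within the scatter). Compound 2 stands clearly apart, with a number 39 percentage points higher from compound 2 to compound 3 (beyond the scatter).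

The next compound is compound 4 `Cn1nccc1[C@@H]1C[C@@](C)(c2ccc(F)cc2F)N=C(N)S1`. Its change is 1-methyl-1H-pyrazol-5-yl in place of 3-methyl-1,2-oxazol-4-yl on a saturated ring carbon, next to the ring sulfur. Within the data shown here, no measured step makes this exact exchange, so the evidence is indirect. Dropping a methyl from the aromatic ring gave a number 8 percentage points higher from compound 1 to compound 3 (within the scatter), a change that the assay could not resolve. The large steps all involve the ethyl group of compound 2, such as a number 31 percentage points lower from compound 1 to compound 2 (beyond the scatter). Among the measured compounds shown here, compound 4 carries no ethyl group, so that large loss offers no direct precedent. Still, a new ring has not been tested here, which leaves real uncertainty in both directions. A small fall that stays within the scatter is expected, with the estimated change being a number 8 percentage points lower from compound 3 to compound 4 (within the scatter). The estimated value for compound 4 is 72%, with a likely range from 50% to 90%.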

Compound 4, percent of the compound remaining: 72%
For compound 4 middle estimate and measured number coincide at the digits printed, and the stated range covers the measured number.
By their numbers in this assay, from the lowest: compound 2; then compounds 1, 4 and 3 (each within the scatter of the next).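

In this assay, the saturated ring carbon next to the ring sulfur accepts a different kind of five-membered aromatic ring, with the 1-methyl-1H-pyrazol-5-yl group carrying a second nitrogen where the 3-methyl-1,2-oxazol-4-yl group has oxygen (a number 8 percentage points lower from compound 3 to compound 4 (within the scatter)) and showing the same picture against the 3,5-dimethyl-1,2-oxazol-4-yl group (no change at the digits printed from compound 1 to compound 4 (within the scatter)). Among these compounds, earlier steps only altered groups on a 1,2-oxazol-4-yl ring, so this is the first sign that the aromatic ring itself can be exchanged here without a change the assay can resolve. The large gap tied to the 3-ethyl-5-methyl-1,2-oxazol-4-yl group also appears against this new ring (a number 31 percentage points higher from compound 2 to compound 4 (beyond the scatter)), and no measurement shown gives a reason for any of these numbers.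

The compounds shown leave open whether a 1-ethyl-1H-pyrazol-5-yl group would show the same large gap as the ethyl-bearing group does. They also leave open how a phenyl or pyridinyl ring, or a group carrying an amine, would behave at this position.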